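The compounds below may be only part of what the source reports. "The series", "measured", "known", "first", "only" and "open" are said of these compounds alone.

Measured in a toxicity assay on NIH3T3 cells (Mus musculus) for cytotoxicity, read by resazurin assay; a lower number here means that less compound is needed, a higher number that more compound is needed for the effect:
compound 1 `COC(=O)c1ccc(NCc2cncn2Cc2cccc(Cl)c2)cc1-c1ccccc1`: > 10000 nM.
compound 2 `Cc1cccc(-c2cccc(NCc3cncn3Cc3ccccc3)c2)c1`: > 1000 nM.
compound 3 `O=C(OC1CCCCC1)c1ccc(NCc2cncn2Cc2ccc(-c3ccccc3)cc2)cc1-c1ccccc1`: > 10000 nM.

The value of compound 1 in this assay is a limit of the assay, not a number. Compound 2 likewise has a limit as its value. Compound 3 also has a limit as its value. Two of the three values sit at the limit of > 10000 nM in this assay, at which 2 of the 3 values shown sit, and one at the limit of > 1000 nM in this assay, at which 1 of the 3 values shown sits, so compound 1 stands at the upper limit together with compound 3. Within the data shown here, no two measured compounds differ in one place, so no measured step is at hand.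

Compound 4 `COC(=O)c1ccc(NCc2cncn2Cc2ccc(Br)cc2)cc1-c1ccccc1` differs from compound 1 thus: 4-bromophenyl in place of 3-chlorophenyl on a saturated chain carbon bound to an aromatic nitrogen. With every value shown a limit, the step that the limit leaves unreadable from compound 1 to compound 4 is expected to be none beyond the scatter. Compound 4 is expected at 20000 nM, with a range from 8000 nM to 60000 nM, most likely reported only as a limit again.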

Compound 4, half-maximal effective concentration: > 10000 nM
Compound 4 gave a limit, no number; the forecaster's own chance of this, stated with the estimate: 85%; the middle value does not contradict the limit.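

Among these compounds, compound 1 and compound 4 both return only a limit of the assay in this assay, so no step between them can be read. The compounds shown leave open how 3-chlorophenyl and 4-bromophenyl compare, and they offer no numerical value.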